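Replacing Fluoro with Tert-Butyl on the Shared Core

A few compounds are considered here, and "the series" means these few. Any claim that something is new, unique, unknown or untested is made for them only; others in the source may bear on it.

In a functional assay on MCF7 cells (Homo sapiens) for antiproliferative activity, with a stated time of 5 days (a higher number here means a weaker inhibitor, a lower number a stronger inhibitor), compound 1 (`COc1ccc(-c2[nH]c3cc(OC)ccc3c2C=O)cc1`) gives 160 nM and compound 2 (`COc1ccc(-c2[nH]c3cc(F)ccc3c2C=O)cc1`) gives 43 nM. Compound 3 (`COc1ccc(-c2[nH]c3ccc(F)cc3c2C=O)cc1`), which also carries fluoro, gives 240 nM. That value lies within the scatter of compound 1 and well beyond it from compound 2.

Compound 4 (`COc1ccc(-c2[nH]c3ccc(C(C)(C)C)cc3c2C=O)cc1`) follows from compound 3 by one change, tert-butyl in place of fluoro on an aromatic carbon.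

Within the data shown here, only one measured step bears on this, and only indirectly. It is a 3.7-fold lower number from compound 1 to compound 2 (0.57 log units; beyond the scatter), a modest change in which fluoro replaces methoxy. Among the measured compounds shown here, no compound with tert-butyl has been measured, and that step does not involve the carbon changed here. The new change runs the opposite way, from fluoro to a group with more heavy atoms, so a modest rise in the number is expected, with wide uncertainty. The expected step is a 2.1-fold higher number from compound 3 to compound 4 (0.32 log units; beyond the scatter). Compound 4 is estimated at 500 nM, with an expected range of 120 nM to 2500 nM.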

Compound 4, half-maximal inhibitory concentration: 580 nM
Compound 4: middle estimate off by 1.2-fold (0.06 log units), on the low side; low and high end bracket the measured number.
By their numbers in this assay, from the lowest: compound 2; then compounds 1 and 3 (each within the scatter of the next); then compound 4.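

Among these compounds, at this aromatic carbon of the shared core, the exchange of fluoro for tert-butyl in this assay is a 2.4-fold higher number from compound 3 to compound 4 (0.38 log units; beyond the scatter) and is the first measured change here, since the earlier step concerned a different carbon. The step lies beyond the scatter, so the number does respond to the group at this carbon, yet the rise is only modest even though tert-butyl brings four heavy atoms where fluoro brought one. No measurement at hand explains the rise.

As far as these compounds go, with only fluoro and tert-butyl compared here, two groups cannot show a trend at this carbon, and whether an amine, a carboxylic acid or a longer chain would raise or lower the number remains open. Also open, from the compounds shown here alone, is whether tert-butyl would produce a similar step at the carbon that carries fluoro in compound 2.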